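Aryl Sulfonamide Replacing Benzyl Sulfonamide in an Alkynylpyridine Series

The compounds below may be only part of what the source reports. "The series", "measured", "known", "first", "only" and "open" are said of these compounds alone.

Measured compounds:
compound 1 `C(#Cc1ccccn1)C1=CC(Sc2ccc3ccccc3c2)CCC1` — 75 nM
compound 2 `C(#Cc1ccccn1)C1=CC(Nc2cccnc2)CCC1` — 7.3 nM
compound 3 `O=S(=O)(Cc1ccccc1)N1CC=C(C#Cc2ccccn2)CC1` — 389 nM

Three compounds have been run in an assay for displacement of a labelled ligand from metabotropic glutamate receptor 5 (Rattus norvegicus); a higher number here means a weaker inhibitor, a lower number a stronger inhibitor. Compound 1 gives 75 nM and compound 2 gives 7.3 nM. Compound 3, whose core carries a sulfonamide in a ring, gives 389 nM, the highest number of the three, with both other compounds beyond the scatter below it; it is therefore the weakest inhibitor of the set in this assay.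

Compound 4 `O=S(=O)(c1ccc(Br)cc1)N1CC=C(C#Cc2ccccn2)CC1` has not yet been measured. It differs from compound 3 in one place: 4-bromophenyl in place of benzyl on a sulfonyl sulfur. Among the measured compounds shown here, no step between two measured compounds corresponds to this change, so the data give no direct guide to its size or direction. The sulfonamide, the ring and the alkynylpyridine remain as in compound 3.

The author expects compound 4 to stay near compound 3 in this assay, with a step of a 1.3-fold lower number from compound 3 to compound 4 (0.11 log units; within the scatter) that does not clearly exceed the scatter in either direction. On that basis compound 4 is estimated at 300 nM, within a range from 80 nM to 1200 nM.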

Compound 4, inhibition constant: 3.1 nM
Beside the measured number, compound 4's estimate is 97-fold (1.99 log units) above it; the whole stated range lies above it.
By their numbers in this assay, from the lowest: compound 4; then compound 2; then compound 1; then compound 3.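

In this assay, the substituent on the sulfonyl sulfur turns out to matter greatly: with the sulfonamide, the ring and the alkynylpyridine unchanged, 4-bromophenyl in place of benzyl gives a 130-fold lower number from compound 3 to compound 4 (2.10 log units; beyond the scatter) as a single change. The two groups match in heavy-atom count, in having one six-membered aromatic ring of carbon only, and in hydrogen-bond counts, so those counts do not track this large step. Nothing among the data shown explains the step.

The change removes the carbon link to the sulfur and adds bromine in one move, and the compounds shown include no plain phenyl on the sulfonyl sulfur to separate the two. Nor do they show whether 4-chlorophenyl, 4-methoxyphenyl or 4-bromobenzyl at this place would give a similar number.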